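The source may hold more compounds than are shown below. What is called first, only, known or untested is meant among the compounds shown, and "the series" means these compounds.

Compound 1 `CCN(CC)C(=O)CN(c1cc2c(C)nsc2cc1Cl)S(=O)(=O)c1ccc(OC)c(OC)c1` inhibits the receptor in a functional assay on CHO cells for inhibition of Orexin receptor type 2 (Homo sapiens), read by FLIPR and calcium flux (on this read-out higher numbers stand for weaker inhibition and lower numbers for stronger inhibition), with 4.5 nM, and compound 2 `CCN(C(=O)CN(c1cc2c(C)nsc2cc1Cl)S(=O)(=O)c1ccc(OC)c(OC)c1)c1ccccn1` gives 5 nM in this assay, the two numbers lying within the usual scatter of each other. Among the measured compounds shown here, the single measured step, a 1.1-fold higher number from compound 1 to compound 2 (0.05 log units; within the scatter), changes only the amide-type nitrogen. Compound 3 `CCN(CC)C(=O)CN(c1cc(N(C)C)ccc1OC)S(=O)(=O)c1ccc(OC)c(OC)c1` differs from compound 1 by a group of 11 heavy atoms (9 carbon, 1 nitrogen, 1 oxygen; one six-membered aromatic ring of carbon only) in place of a group of 11 heavy atoms (8 carbon, 1 nitrogen, 1 sulfur, 1 chlorine; one five-membered aromatic ring with 2 hetero atoms, one six-membered aromatic ring of carbon only), on a sulfonamide nitrogen. For the measured compounds named here, no measured step touches the sulfonamide nitrogen, so the size and direction of this change are unknown, and a wide range is needed. Compound 3 is expected to give 40 nM in this assay, between 5 nM and 400 nM. The expected step is an 8.9-fold higher number from compound 1 to compound 3 (0.95 log units; beyond the scatter).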

Compound 3, half-maximal inhibitory concentration: 239 nM
Estimate against measurement, compound 3: 6.0-fold (0.78 log units) below; the range from low to high includes it.
By their numbers in this assay, from the lowest: compounds 1 and 2 (each within the scatter of the next); then compound 3.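

The sulfonamide nitrogen is the first place shown where a change moves the number in this assay beyond the scatter: putting 5-(dimethylamino)-2-methoxyphenyl there brings a 53-fold higher number from compound 1 to compound 3 (1.73 log units; beyond the scatter), a large loss of inhibition. The two groups have equal counts of heavy atoms and hydrogen-bond acceptors, so those counts alone do not settle the number at this position. Nothing measured here explains the loss. Still open, on these data alone, is which part of the exchanged group matters, and how a plain phenyl or a chlorophenyl group would fare on this nitrogen.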